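A few compounds are considered here, and "the series" means these few. Any claim that something is new, unique, unknown or untested is made for them only; others in the source may bear on it.

Compound 1 `Nc1ccc(-c2nnc(SC3=CS(=O)(=O)c4ccccc43)o2)cc1` is the reference point of the set. In an ADME assay on HepG2 cells (Homo sapiens) for cytotoxicity, read by fluorescence and resazurin assay, with a stated time of 24 h (on this read-out higher numbers stand for lower toxicity in this test and lower numbers for higher toxicity in this test), compound 1 gives 24000 nM. The other two compounds differ from it only in the aryl group on the shared core. Compound 2 `COc1ccccc1-c1nnc(SC2=CS(=O)(=O)c3ccccc32)o1` gives 16000 nM, and compound 3 `COC(=O)c1ccc(-c2nnc(SC3=CS(=O)(=O)c4ccccc43)o2)cc1` gives 18000 nM. Both of these numbers sit within the scatter of compound 1: the steps are a 1.5-fold lower number from compound 1 to compound 2 (0.18 log units; within the scatter) and a 1.3-fold lower number from compound 1 to compound 3 (0.12 log units; within the scatter), so the three compounds cannot be ordered on this read-out.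

Compound 4 `O=S1(=O)C=C(Sc2nnc(-c3cccc(Cl)c3)o2)c2ccccc21` has not been measured. It differs from compound 1 in one place: 3-chlorophenyl in place of 4-aminophenyl on an aromatic carbon. Going by the values given here, no measured step makes this exact exchange. The two steps that do vary the aryl group on the same position, from compound 1 to compound 2 and from compound 1 to compound 3, both stay within the scatter, so no step beyond the scatter is expected for compound 4 either. Compound 4 is therefore expected to give about 20000 nM, with a range of 8000 nM to 50000 nM. The expected step is a 1.2-fold lower number from compound 1 to compound 4 (0.08 log units; within the scatter).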

Compound 4, half-maximal cytotoxic concentration: 27000 nM
Estimate against measurement, compound 4: 1.4-fold (0.13 log units) below; the measured number falls inside the stated range.
By their numbers in this assay, from the lowest: compounds 2, 3, 1 and 4 (each within the scatter of the next).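

In this assay the exchange of 4-aminophenyl for 3-chlorophenyl gives a 1.1-fold higher number from compound 1 to compound 4 (0.05 log units; within the scatter) on this carbon of the five-membered ring, so an aryl group with a chlorine and with no hydrogen-bond donors or acceptors reads the same as the aminophenyl group. The step from the 2-methoxyphenyl group is a 1.7-fold higher number from compound 2 to compound 4 (0.23 log units; within the scatter) and also leaves the number unresolved, which extends the flat picture to a third substitution pattern on the phenyl ring. No measured information bears on why these aryl exchanges leave the read-out unmoved.

On these data alone, no group on this carbon has yet produced a step beyond the scatter, so what would move this read-out remains unknown. A carboxylic acid on the phenyl ring, or a piperidine or a short alkyl chain in place of the phenyl ring, would test how far this flat picture extends.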